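Ester to free alcohol on the acetoxymethyl side chain

A few compounds are considered here, and "the series" means these few. Any claim that something is new, unique, unknown or untested is made for them only; others in the source may bear on it.

In a functional assay on HL-60 cells (Homo sapiens) for antiproliferative activity, read by MTT assay, with a stated time of 6 days (on this read-out higher numbers stand for weaker inhibition and lower numbers for stronger inhibition), compound 1 `O=C1C=C[C@@H](OCc2ccccc2)[C@@H]([C@@H](COC(=O)/C=C/c2ccc(F)cc2)OCc2ccccc2)O1` gives 5400 nM. Within the data shown here, compound 2 `CC(=O)OC[C@@H](OCc1ccccc1)[C@H]1OC(=O)C=C[C@H]1OCc1ccccc1` gives 9230 nM, the higher of the two numbers, its only neighbour being compound 1; the step of a 1.7-fold higher number from compound 1 to compound 2 (0.23 log units; within the scatter). Compound 3 `O=C1C=C[C@@H](OCc2ccccc2)[C@@H]([C@@H](CO)OCc2ccccc2)O1` differs from compound 2 by hydrogen in place of acetyl on an oxygen on a saturated carbon. Among the measured compounds shown here, only that one measured step bears on this change: exchanging the acyl group left the number within the scatter, so removing it is expected to move the number little, if anything upward. Compound 3 is therefore estimated at 11000 nM, in the range 4000 nM to 30000 nM. The expected step of a 1.2-fold higher number from compound 2 to compound 3 (0.08 log units; within the scatter) is thus taken to stay within the scatter.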

Compound 3, half-maximal inhibitory concentration: 10200 nM
Compound 3: the middle estimate sits 1.1-fold (0.03 log units) above what was measured, and the stated range covers the measured number.
By their numbers in this assay, from the lowest: compounds 1, 2 and 3 (each within the scatter of the next).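

Acetoxy to hydroxy on this side chain gives the step (a 1.1-fold higher number from compound 2 to compound 3 (0.04 log units; within the scatter)), and hydrogen in place of (2-(4-fluorophenyl)ethenyl)carbonyl on the same oxygen gives the step (a 1.9-fold higher number from compound 1 to compound 3 (0.28 log units; within the scatter)). The earlier pair exchanged one acyl group for another; these steps show that the free alcohol also stays within the scatter of both esters, so across these three compounds an acyl group on this oxygen is not needed to keep the number in this range. No supporting data bear on why this is so. On these data alone, whether an amine or a carboxylic acid in place of the hydroxy would take the number beyond the scatter remains open.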